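Chain-end ester on the pentyl ether of compound 3

A few compounds are considered here, and "the series" means these few. Any claim that something is new, unique, unknown or untested is made for them only; others in the source may bear on it.

Compound 1 `C=CCc1cc(C(C)=O)c(O)cc1OCCCCC#N`: 57%
Compound 2 `C=CCc1cc(C(C)=O)c(O)cc1OCCCCCCC#N`: 63%
Compound 3 `C=CCc1cc(C(C)=O)c(O)cc1OCCCCC`: 23%

In an assay on isolated protein for binding affinity to leukotriene B4 receptor 1 (Homo sapiens), tested at 1 uM (on this read-out lower numbers stand for less inhibition and higher numbers for more inhibition at the one concentration tested (going by the name of the read-out)), compound 3 gives 23%, the lowest of the three numbers, with compound 1 and compound 2 both beyond the scatter above it. Compound 4 `C=CCc1cc(C(C)=O)c(O)cc1OCCCCCC(=O)OC` differs from compound 3 by methoxycarbonyl in place of hydrogen on a saturated chain carbon, five bonds along the chain from an oxygen on an aromatic ring.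

For the measured compounds named here, two measured steps bear on this change, since each ends at compound 3 and removes a nitrile-bearing chain end: a number 34 percentage points lower from compound 1 to compound 3 (beyond the scatter) and a number 40 percentage points lower from compound 2 to compound 3 (beyond the scatter). Read in reverse, adding such a chain end to the saturated chain raised the number in this assay by a large amount in both cases, and the two nitrile compounds differ only by a number 6 percentage points higher from compound 1 to compound 2 (within the scatter), so chain length mattered little. Going by the values given here, compound 4 likewise adds a group bearing acceptors at the chain end, though an ester rather than a nitrile, and no measured pair shows an ester directly. A rise beyond the scatter is therefore expected, somewhat smaller than the nitrile steps to allow for the different group. Compound 4 is expected to give 50%, in the range 30% to 70%. This estimate corresponds to an expected step of a number 27 percentage points higher from compound 3 to compound 4 (beyond the scatter).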

Compound 4, a percentage reported as inhibition, at one concentration (the size of the read-out at that concentration, not a potency): 65%
For compound 4 the middle estimate is 15 percentage points below the measured one; the range from low to high includes it.
By their numbers in this assay, from the lowest: compound 3; then compounds 1, 2 and 4 (each within the scatter of the next).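

In this assay, for the compounds shown here, methoxycarbonyl in place of hydrogen on a saturated chain carbon, five bonds along the chain from an oxygen on an aromatic ring, gives a number 42 percentage points higher from compound 3 to compound 4 (beyond the scatter) and so shows that the rise over the pentyl ether is not confined to chains ending in a nitrile, which the earlier compounds could not show. Set against those nitrile compounds, the ester does not separate from either: replacing cyanomethyl with methoxycarbonyl gives a number 2 percentage points higher from compound 2 to compound 4 (within the scatter) and replacing cyano with (methoxycarbonyl)methyl gives a number 8 percentage points higher from compound 1 to compound 4 (within the scatter), so the three chain ends cannot be told apart in this read-out. No supporting data are available to explain the rise or the likeness of the ester and nitrile chain ends.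

The compounds shown leave open whether a carboxylic acid or a primary amide at the same chain end would keep the number near that of the methyl ester. Going by these compounds alone, they also leave open how the methyl ester would fare on a shorter or longer chain, as only one chain length carries it here.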